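The compounds below may be only part of what the source reports. "The series", "measured", "known", "first", "only" and "open" are said of these compounds alone.

Measured so far:
- compound 1, `O=C(O)CCc1ccc(NCc2ccc(Cl)cc2)cc1`: 111%
- compound 2, `O=C(O)CCc1ccc(NCc2ccc(Cl)c(Cl)c2)cc1`: 117%
- compound 3, `O=C(O)CCc1ccc(NCc2ccc(C(F)(F)F)cc2)cc1`: 133%

In a functional assay on CHO cells for agonist activity at Free fatty acid receptor 1 (Homo sapiens), read by reporter gene assay (on this read-out lower numbers stand for smaller maximal responses and higher numbers for larger maximal responses), compound 3 stands highest of the three, and its distance to compound 2 and to compound 1 lies beyond the scatter. The two measured steps both start from compound 1: a number 6 percentage points higher from compound 1 to compound 2 (within the scatter) and a number 22 percentage points higher from compound 1 to compound 3 (beyond the scatter). Compound 4, `O=C(O)CCc1ccc(NCc2ccc(C(=O)O)cc2)cc1`, has not yet been measured. It differs from compound 3 in one place: carboxy in place of trifluoromethyl on an aromatic carbon.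

Among the measured compounds shown here, neither measured step touches a carboxy group, so no step among the measured compounds speaks directly to this change. The step from compound 1 to compound 3 shows that swapping the group at this position can move the maximal response by a modest amount, and the step from compound 1 to compound 2 shows a swap at a neighbouring position staying within the scatter. The change into compound 4 is of a different kind from both, so the estimate must be broad. A downward step of a number 43 percentage points lower from compound 3 to compound 4 (beyond the scatter) is expected because compound 3 gives 133%, the largest measured value, which leaves more room below than above. Compound 4 is therefore estimated at 90%, with a range from 55% to 125%.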

Compound 4, largest response reached (reported as percent of maximum), in percent of the reference or control that the assay uses: 9%
The estimate for compound 4 lay 81 percentage points above the measured number; measured number outside the range, below it.
By their numbers in this assay, from the lowest: compound 4; then compounds 1 and 2 (each within the scatter of the next); then compound 3.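

In this assay, this change shows that the group on the aromatic carbon para to a large group can do far more than adjust the maximal response: carboxy in place of trifluoromethyl gives a number 124 percentage points lower from compound 3 to compound 4 (beyond the scatter), and carboxy in place of chloro gives a number 102 percentage points lower from compound 1 to compound 4 (beyond the scatter). The earlier swaps had moved the response by a modest amount at most, and all three earlier compounds stayed high, so they gave no sign that a single replacement here could leave compound 4 at 9% with the rest of the structure unchanged. The large fall appears whether the group leaving is trifluoromethyl or chloro, yet nothing available gives a measured reason for it.

The compounds shown leave open whether the loss belongs to the carboxy group as such or would also follow with a methyl ester, a primary amide or a tetrazole at this place. They also leave open whether a longer chain carrying the carboxylic acid, or an amine in its stead, would restore the response, and how any such group would fare on a read-out other than the maximal response.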